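A few compounds are considered here, and "the series" means these few. Any claim that something is new, unique, unknown or untested is made for them only; others in the source may bear on it.

In a toxicity assay on MT4 cells (Homo sapiens) for cytotoxicity, read by MTT assay (on this read-out lower numbers stand for higher toxicity in this test and higher numbers for lower toxicity in this test), compound 1 `O=c1nc(O)ccn1[C@H]1C=C[C@]2(CO)C[C@H]12` gives > 100 ug/mL, which is a limit of the assay and not a number. Compound 2 `Cc1cn([C@@H]2C=C[C@@]3(CO)C[C@@H]23)c(=O)[nH]c1=O` gives > 100 ug/mL, again a limit. Compound 3 `Cc1cn([C@H]2C=C[C@]3(CO)C[C@H]23)c(=O)[nH]c1=O` gives a number, 8.56 ug/mL. Going by the values given here, the only measured step, an at least 11-fold lower number from compound 2 to compound 3 (1.06 log units; beyond the scatter), is large and beyond the scatter, and it comes with the fact that compounds 2 and 3 differ only in the configuration as drawn.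

Compound 4 `Nc1ccn([C@H]2C=C[C@]3(CO)C[C@H]23)c(=O)n1` differs from compound 1 by amino in place of hydroxy on an aromatic carbon. Among the compounds with values here, no measured step makes this exchange of hydroxy for amino, so the evidence is indirect. With only an at least 11-fold lower number from compound 2 to compound 3 (1.06 log units; beyond the scatter) to go on, a move to a lower number is expected for compound 4, smaller than that step. The expected change is an at least 2.0-fold lower number from compound 1 to compound 4 (0.30 log units; that floor lies within the scatter), estimated from a limit alone. Compound 4 is expected at 50 ug/mL, with an estimated range of 8 ug/mL to 200 ug/mL.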

Compound 4, half-maximal cytotoxic concentration: 61.8 ug/mL
Estimate against measurement, compound 4: 1.2-fold (0.09 log units) below; low and high end bracket the measured number.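

With amino in place of hydroxy on an aromatic carbon, the shared core now shows a change of group rather than of configuration, and it gives an at least 1.6-fold lower number from compound 1 to compound 4 (0.20 log units; that floor lies within the scatter). Compound 4 has a real number in this assay, so this group sets a reference point for the position. Compound 1 remains at a limit, so the step has only a floor and its true size cannot be read: the limit of > 100 ug/mL in this assay, at which 2 of the 4 values shown sit.

The compounds shown leave open how a methylamino or methoxy group on this aromatic carbon would read. They also leave open whether the mirror image of compound 4 would read differently.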